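The source may report more compounds than this note shows. Statements on the series, on what has been measured and on what is new or still open speak of the compounds shown alone.

Compound 1 `COc1cc(N(Cc2ccc(C)cc2)C(=O)CSc2nc3ccccc3s2)cc(OC)c1OC` carries a 4-methylbenzyl group on its amide-type nitrogen. In a functional assay on PC-3 cells (Homo sapiens) for antiproliferative activity, read by MTT assay, with a stated time of 48 h (on this read-out higher numbers stand for weaker inhibition and lower numbers for stronger inhibition), compound 1 gives > 80000 nM, which is a limit of the assay rather than a number, as shown by the limit of > 80000 nM in this assay, at which 1 of the 2 values shown sits. Compound 2 `COc1ccc(CN(C(=O)CSc2nc3ccccc3s2)c2cc(OC)c(OC)c(OC)c2)cc1O` shares the same core; in this assay compound 2 gives 2110 nM. Among the measured compounds shown here, the one measured step, an at least 37-fold lower number from compound 1 to compound 2 (1.57 log units; beyond the scatter), comes from a 3-hydroxy-4-methoxyphenyl in place of 4-methylphenyl on a saturated chain carbon bound to an amide-type nitrogen, a change that adds a hydroxy and a methoxy group.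

Compound 3 `COc1cc(N(Cc2ccc(F)cc2)C(=O)CSc2nc3ccccc3s2)cc(OC)c1OC` differs from compound 1 by fluoro in place of methyl on an aromatic carbon. For the measured compounds named here, this swap of one small group for another on the 4-methylphenyl ring has no measured counterpart here; the only measured step involves a different and larger change. Compound 3 is therefore expected to sit near compound 1, with a step that the limit leaves unreadable from compound 1 to compound 3 and a good chance of again reaching only a limit. The estimate for compound 3 in this assay is 90000 nM, with a range from 30000 nM to 250000 nM.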

Compound 3, half-maximal inhibitory concentration: 50800 nM
The estimate for compound 3 lay 1.8-fold (0.25 log units) above the measured number, and the stated range covers the measured number.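

Swapping methyl for fluoro on the aromatic ring gives an at least 1.5-fold lower number from compound 1 to compound 3 (0.19 log units; that floor lies within the scatter), so the true size of this small swap stays unknown, although compound 3 does give a real number in this assay. That step is only a floor because compound 1 rests at a limit of the assay rather than at a number: the limit of > 80000 nM in this assay, at which 1 of the 3 values shown sits. The second comparison gives a 24-fold higher number from compound 2 to compound 3 (1.38 log units; beyond the scatter), so the 3-hydroxy-4-methoxyphenyl ring of compound 2 stands well clear of a second simple ring, 4-fluorophenyl, and not only of 4-methylphenyl.

The compounds shown leave open whether the hydroxy or the methoxy group of compound 2 matters more, as the two appear only together. From the compounds shown here alone, how an amine or a carboxylic acid on this ring would read also remains open.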